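Furan to imidazole on the piperazine benzyl arm

The compounds below may be only part of what the source reports. "The series", "measured", "known", "first", "only" and "open" are said of these compounds alone.

Measured so far:
compound 1 `Cc1ccc(CN2CCN(c3cccc4[nH]c(-c5ccc(C(C)(C)C)cc5)nc34)CC2)o1` gives 705 nM in an assay on isolated protein for displacement of a labelled ligand from Gonadotropin-releasing hormone receptor (Homo sapiens); on this read-out higher numbers stand for weaker inhibition and lower numbers for stronger inhibition
compound 2 `Cn1cnc(CN2CCN(c3cccc4[nH]c(-c5ccc(C(C)(C)C)cc5)nc34)CC2)c1` gives 33 nM in this assay

Compound 1 stands highest of the two numbers, weakest of the pair. Compound 3 `Cc1nc(CN2CCN(c3cccc4[nH]c(-c5ccc(C(C)(C)C)cc5)nc34)CC2)c[nH]1` carries the change (2-methyl-1H-imidazol-4-yl in place of 5-methylfuran-2-yl on a saturated chain carbon bound to an amine nitrogen in a ring). For the measured compounds named here, the one step that bears on it, a 21-fold lower number from compound 1 to compound 2 (1.33 log units; beyond the scatter), swaps the same furan for a closely related imidazole and is large. A drop of comparable size is therefore expected for compound 3, though with wider uncertainty since the imidazole differs. Compound 3 is estimated at 50 nM, within 15 nM to 200 nM, meaning an expected step of a 14-fold lower number from compound 1 to compound 3 (1.15 log units; beyond the scatter).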

Compound 3, half-maximal inhibitory concentration: 7.5 nM
Beside the measured number, compound 3's estimate is 6.7-fold (0.82 log units) above it, and the stated range ends above it.
By their numbers in this assay, from the lowest: compound 3; then compound 2; then compound 1.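

Replacing 5-methylfuran-2-yl with 2-methyl-1H-imidazol-4-yl on this saturated chain carbon gives a 94-fold lower number from compound 1 to compound 3 (1.97 log units; beyond the scatter), so the large gain seen with compound 2 extends to a second imidazole. The two imidazoles are not interchangeable here, with a 4.4-fold lower number from compound 2 to compound 3 (0.64 log units; beyond the scatter) separating them, which shows that the arrangement of methyl and ring nitrogens on the imidazole changes the read-out. No supporting measurement accounts for either step. Still open, from the compounds shown here alone, is how an unsubstituted 1H-imidazol-4-yl or a pyridin-2-yl ring would read on the same carbon.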